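Shifting a Methoxy Group in a Cytotoxicity Series

A few compounds are considered here, and "the series" means these few. Any claim that something is new, unique, unknown or untested is made for them only; others in the source may bear on it.

Of the compounds shown here, three sharing one core have been measured in a functional assay on Caco-2 cells (Homo sapiens) for cytotoxicity, with a stated time of 48 h; a higher number here means a weaker inhibitor, a lower number a stronger inhibitor. Compound 1 `O=[N+]([O-])c1ccc(CN2CCC(n3cc(CC(OCc4cc(-c5ccccc5)no4)c4ccc(Br)cc4)nn3)CC2)cc1` gives 7000 nM. Compound 2 `O=[N+]([O-])c1ccc(CN2CCC(n3cc(CC(OCc4cc(-c5ccc(F)cc5)no4)c4ccc(Br)cc4)nn3)CC2)cc1`, which carries fluoro in place of hydrogen on an aromatic carbon, gives 3000 nM, and the step of a 2.3-fold lower number from compound 1 to compound 2 (0.37 log units; beyond the scatter) lies beyond the scatter. Compound 3 `COc1cccc(-c2cc(COC(Cc3cn(C4CCN(Cc5ccc([N+](=O)[O-])cc5)CC4)nn3)c3ccc(Br)cc3)on2)c1` gives 5000 nM; the step of a 1.4-fold lower number from compound 1 to compound 3 (0.15 log units; within the scatter) stays within the scatter, as does a 1.7-fold higher number from compound 2 to compound 3 (0.22 log units; within the scatter). Compound 2 thus has the lowest of the three numbers, but only its gap to compound 1 is beyond the scatter, so it cannot be set apart from compound 3.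

Compound 4 `COc1ccccc1-c1cc(COC(Cc2cn(C3CCN(Cc4ccc([N+](=O)[O-])cc4)CC3)nn2)c2ccc(Br)cc2)on1` has not yet been measured. Its difference from compound 2 is 2-methoxyphenyl in place of 4-fluorophenyl on an aromatic carbon. Within the data shown here, the steps that bear on this change are the fluoro step a 2.3-fold lower number from compound 1 to compound 2 (0.37 log units; beyond the scatter), which was modest, and the two methoxy-bearing steps a 1.4-fold lower number from compound 1 to compound 3 (0.15 log units; within the scatter) and a 1.7-fold higher number from compound 2 to compound 3 (0.22 log units; within the scatter), both within the scatter. Nothing among these three compounds shows a methoxyphenyl group moving the number beyond the scatter, so compound 4 is expected to land near compound 2, with a somewhat higher number more likely than a lower one. The expected step is a 1.5-fold higher number from compound 2 to compound 4 (0.18 log units; within the scatter). Compound 4 is estimated at 4500 nM, within a range from 2000 nM to 10000 nM.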

Compound 4, half-maximal inhibitory concentration: > 25000 nM
Compound 4: no number, only a limit (the forecaster's own chance of this, stated with the estimate: 5%); middle value at least 5.5-fold (0.74 log units) from the limit.
By their numbers in this assay, from the lowest: compounds 2, 3 and 1 (each within the scatter of the next, the first and the last beyond it). At a limit, above all of these: compound 4.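

In this assay, compound 4 gives no number, only a limit of the assay: the limit of > 25000 nM in this assay, at which 1 of the 4 values shown sits.

The earlier compounds shown here showed no methoxy-bearing step beyond the scatter, but on this aromatic carbon, next to the ring nitrogen, exchanging 3-methoxyphenyl for 2-methoxyphenyl gives an at least 5.0-fold higher number from compound 3 to compound 4 (0.69 log units; beyond the scatter), so the same methoxy group on the same phenyl ring does not read the same in both compounds. The 2-methoxyphenyl group also separates from the other two groups at this carbon, with an at least 3.5-fold higher number from compound 1 to compound 4 (0.55 log units; beyond the scatter) against the unsubstituted phenyl and an at least 8.3-fold higher number from compound 2 to compound 4 (0.92 log units; beyond the scatter) against 4-fluorophenyl, so this position tolerates some changes with little movement in the number but not this one.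

Going by these compounds, since compound 4 stands at a limit, the true size of these steps stays open, and the four compounds cannot say whether the methoxy group itself matters or whether any group on that ring carbon would do the same. A methyl group, a chlorine atom or an ethoxy group in place of the methoxy on that ring carbon would bear on this question, and none of these is among the compounds shown.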